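This account rests on a few compounds, and the source may have more. Where it says the series, first, only, none or still open, it means among the compounds named here.

Working notes on the series. Compound 1 `CC(=O)c1cccc(-c2ccc(C(=O)N(Cc3cccc(OCCCCCC(=O)O)c3)C(C)C)cc2)c1`, compound 2 `CCOC(=O)CCCCCOc1cccc(CN(C(=O)c2ccc(-c3cccc(C(C)=O)c3)cc2)C(C)C)c1` and compound 3 `CCOC(=O)CCCCCOc1cccc(CN(C(=O)c2ccc(-c3cccc(OCc4ccccc4)c3)cc2)C(C)C)c1` share one amide core and have been run in an ADME assay on HEK293 cells (Homo sapiens) for cytotoxicity, read by CellTiter-Glo and resazurin assay, with a stated time of 72 h; on this read-out higher numbers stand for an effect only at larger amounts of compound and lower numbers for an effect already at smaller amounts. For compound 1 the read-out is a limit of the assay, > 26000 nM. For compound 2 the read-out is likewise a limit, > 26000 nM. For compound 3 the read-out is again a limit, > 26000 nM. Compound 2 thus stands at the same limit as its two neighbours in this assay, with no number to separate them. The step that the two limits leave unreadable from compound 1 to compound 2 and the step that the two limits leave unreadable from compound 2 to compound 3 are not readable.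

Compound 4 `CCOC(=O)CCCCCOc1cccc(CN(C(=O)c2ccc(-c3ccc4c(c3)OCCO4)cc2)C(C)C)c1` differs from compound 2 by 2,3-dihydro-1,4-benzodioxin-6-yl in place of 3-acetylphenyl on an aromatic carbon. Going by the values given here, the only evidence that bears on this change is the limit of > 26000 nM in this assay, at which 3 of the 3 values shown sit: every measured compound, whatever group occupies this place on the shared core, reaches the limit without a read number. Among the compounds with values here, no measured step tells how large a move the exchange of 3-acetylphenyl for 2,3-dihydro-1,4-benzodioxin-6-yl would produce, so the expectation rests on the three limits alone. In this assay compound 4 is expected to give 30000 nM, with a range from 15000 nM to 80000 nM. The step that the limit leaves unreadable from compound 2 to compound 4 that this estimate means is expected to be none beyond the scatter, and a limit rather than a number is the likely outcome.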

Compound 4, half-maximal effective concentration: > 24400 nM
Compound 4: no number, only a limit; the forecaster's own chance of this, stated with the estimate: 85%; the middle value does not contradict the limit.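

Compound 4 in this assay gives > 24400 nM, which is a limit of the assay and not a number. Going by these compounds alone, compound 2 also stands at a limit, so no step between compound 2 and compound 4 can be read. The compounds shown leave open at what concentration any of them takes effect in this assay, and whether the group at this place alters it.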